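Oxindole-thiazolone pyrazolines: aryl swap at the saturated carbon

The source may report more compounds than this note shows. Statements on the series, on what has been measured and on what is new or still open speak of the compounds shown alone.

Measured so far:
- compound 1 `O=C1N=C(N2N=C(c3ccccc3)CC2c2ccccc2O)S/C1=C1/C(=O)Nc2ccccc21` — 2070 nM
- compound 2 `O=C1N=C(N2N=C(c3ccccc3)CC2c2ccccc2O)S/C1=C1/C(=O)Nc2ccc(Br)cc21` — 230 nM
- compound 3 `COc1ccc(C2=NN(C3=NC(=O)/C(=C4\C(=O)Nc5ccc(Cl)cc54)S3)C(c3ccc(Cl)cc3)C2)cc1` — 200 nM

In a functional assay on cells (Cancer cell lines, Homo sapiens) for cytotoxicity, read by sulforhodamine B assay, with a stated time of 48 h (a lower number here means a stronger inhibitor of growth, a higher number a weaker inhibitor of growth), compound 1 gives the highest number of the three; compound 2 lies nearest and compound 3 furthest, both well beyond the scatter. Going by the values given here, the one single-point step on record is a 9.0-fold lower number from compound 1 to compound 2 (0.95 log units; beyond the scatter), a change elsewhere on the shared core and so not on the position altered here.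

Compound 4 `CN(C)c1ccc(C2CC(c3ccccc3)=NN2C2=NC(=O)/C(=C3\C(=O)Nc4ccccc43)S2)cc1` is not yet measured. Relative to compound 1 the change is 4-(dimethylamino)phenyl in place of 2-hydroxyphenyl on a saturated ring carbon. Among the compounds with values here, no measured pair isolates this position. Compound 3, which carries a 4-chlorophenyl on that saturated ring carbon but also differs at two further places, gives 200 nM against 2070 nM for compound 1; with three changes at once this shows nothing about the aryl swap alone. Within the data shown here, with no step that bears on it, the expectation for this assay is no change beyond the scatter, with a wide range. Compound 4 is therefore estimated at 1500 nM, range 400 nM to 5000 nM, which means an expected step of a 1.4-fold lower number from compound 1 to compound 4 (0.14 log units; within the scatter).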

Compound 4, concentration for 50% growth inhibition: 6370 nM
Beside the measured number, compound 4's estimate is 4.2-fold (0.63 log units) below it, outside the stated range (above it).
By their numbers in this assay, from the lowest: compounds 3 and 2 (each within the scatter of the next); then compound 1; then compound 4.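

In this assay, going by these compounds alone, the aryl group on the saturated ring carbon is isolated for the first time, and the swap of 2-hydroxyphenyl for 4-(dimethylamino)phenyl gives a 3.1-fold higher number from compound 1 to compound 4 (0.49 log units; beyond the scatter), so this position does respond to a change of aryl group on the shared core. The swap alters both the substituent and its place on the phenyl ring, and this single step cannot separate the two. No measurement on hand bears on the reason for the step.

A 4-hydroxyphenyl or a 2-(dimethylamino)phenyl on this carbon would separate the substituent from its place on the ring, and neither is among the compounds shown. On these data alone, whether the step carries over to the bromo-bearing core of compound 2 also remains open.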